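Trimming an Amine Side Chain and Lipophilicity

The source may hold more compounds than are shown below. What is called first, only, known or untested is meant among the compounds shown, and "the series" means these compounds.

Compound 1 `Cc1csc2cc([C@H](C)Nc3ncnc(N)c3C#N)c(-c3cccc(CN4CCC(N(C)CC(C)C)CC4)c3)c(=O)n12` and compound 2 `Cc1csc2cc([C@H](C)Nc3ncnc(N)c3C#N)c(-c3cccc(CN4CCC(N(C)C)CC4)c3)c(=O)n12` share a core and differ by one change, (hydrogen in place of isopropyl on a saturated chain carbon bound to an amine nitrogen). In a physicochemical assay for lipophilicity (on this read-out higher numbers stand for higher lipophilicity and lower numbers for lower lipophilicity), compound 1 gives 1.7, and compound 2 gives 0.5; the step is a number 1.20 log units lower from compound 1 to compound 2 (beyond the scatter).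

Compound 3 `Cc1csc2cc([C@H](C)Nc3ncnc(N)c3C#N)c(Cc3cccc(CN(C)CC(C)C)c3)c(=O)n12` carries a different core; how its core differs from that of compound 1 is not broken down here. In this assay compound 3 gives 2.3, the highest of the three numbers, lying beyond the scatter above compound 1 and further still above compound 2.

Compound 4 `Cc1csc2cc([C@H](C)Nc3ncnc(N)c3C#N)c(Cc3cccc(CN(C)C)c3)c(=O)n12` has not been measured. It differs from compound 3 by hydrogen in place of isopropyl on a saturated chain carbon bound to an amine nitrogen, the same change as between compound 1 and compound 2, at the same kind of position. Because the change from compound 1 to compound 2 gave a number 1.20 log units lower from compound 1 to compound 2 (beyond the scatter), the step from compound 3 to compound 4 is expected to be of similar size, a number 1.20 log units lower from compound 3 to compound 4 (beyond the scatter). On that basis compound 4 is estimated at 1.1 in this assay, most likely between 0.7 and 1.5.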

Compound 4, distribution coefficient: 0.8
Compound 4: the middle estimate sits 0.30 log units above what was measured, within the range that was stated.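

In this assay the same swap of isopropyl for hydrogen, on a saturated chain carbon bound to an amine nitrogen, gives a number 1.50 log units lower from compound 3 to compound 4 (beyond the scatter) and a number 1.20 log units lower from compound 1 to compound 2 (beyond the scatter) on the two cores, so the change keeps its direction and both steps are large. These two pairs support carrying the change between these two cores, but two pairs set no rule for any other core or any other side chain. Nothing shown explains why the number falls in either pair.

The compounds shown leave open whether the number would fall in the same way if a longer chain such as hexyl, or a carboxylic acid, stood in place of the isopropyl. They also leave open whether a smaller step down, from isopropyl to ethyl, would take only part of the fall, and whether a third core would follow these two.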